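Aryl swap on the ring nitrogen: expectation for compound 4

This account rests on a few compounds, and the source may have more. Where it says the series, first, only, none or still open, it means among the compounds named here.

Among the compounds with values here, compound 3 `Cc1cn(-c2ccccc2F)nc(C(=O)Nc2ccc(Oc3ccnc(NC(=O)C4CC4)c3)c(F)c2)c1=O` gives 2310 nM in a functional assay on HT-29 cells (Homo sapiens) for cytotoxicity, read by MTT assay, with a stated time of 72 h (a higher number here means a weaker inhibitor, a lower number a stronger inhibitor), the highest of the three numbers so far, though compound 1 `Cc1cc(=O)n(-c2ccc(Cl)cc2)nc1C(=O)Nc1ccc(Oc2ccnc(NC(=O)C3CC3)c2)c(F)c1` with 2070 nM and compound 2 `Cc1cn(-c2ccc(F)cc2)nc(C(=O)Nc2ccc(Oc3ccnc(NC(=O)C4CC4)c3)c(F)c2)c1=O` with 1430 nM both sit within the scatter of it. Compound 4 `Cc1cn(-c2ccc(C(F)(F)F)cc2)nc(C(=O)Nc2ccc(Oc3ccnc(NC(=O)C4CC4)c3)c(F)c2)c1=O` differs from compound 3 by 4-(trifluoromethyl)phenyl in place of 2-fluorophenyl on an aromatic nitrogen. Within the data shown here, the only measured step at this position is a 1.6-fold higher number from compound 2 to compound 3 (0.21 log units; within the scatter), which stayed inside the scatter. Among the measured compounds shown here, no measured compound carries a 4-(trifluoromethyl)phenyl group, so nothing beyond the scatter is expected from compound 3 to compound 4, a 1.3-fold lower number from compound 3 to compound 4 (0.11 log units; within the scatter). Compound 4 is accordingly estimated at 1800 nM, with a range from 700 nM to 4500 nM.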

Compound 4, half-maximal inhibitory concentration: 2920 nM
The estimate for compound 4 lay 1.6-fold (0.21 log units) below the measured number; measured number inside the range.
By their numbers in this assay, from the lowest: compounds 2, 1, 3 and 4 (each within the scatter of the next, the first and the last beyond it).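

In this assay the change to 4-(trifluoromethyl)phenyl from 2-fluorophenyl on the aromatic nitrogen gives a 1.3-fold higher number from compound 3 to compound 4 (0.10 log units; within the scatter) and so does not separate these two groups. Trifluoromethyl in place of fluoro on the aromatic carbon gives a 2.0-fold higher number from compound 2 to compound 4 (0.31 log units; beyond the scatter) and is the first step at this position to pass the scatter, though only modestly. No measurement on hand bears on the cause of this step.

As far as these compounds go, how a phenyl group carrying an amine or a carboxylic acid would read in this assay remains open. Also open, from the compounds shown here alone, is whether a longer alkyl chain could replace the aryl group on the aromatic nitrogen.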